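Phenylsulfonyl on the aromatic nitrogen of compound 1

A few compounds are considered here, and "the series" means these few. Any claim that something is new, unique, unknown or untested is made for them only; others in the source may bear on it.

Compound 1 `Cc1ccc(-c2nn(-c3ccccc3)cc2-c2nc3ccccc3[nH]2)cc1` gives 187000 nM in an ADME assay on HEK-293T cells (Homo sapiens) for cytotoxicity, read by MTT assay, with a stated time of 24 h (a higher number here means that more compound is tolerated, a lower number that less compound is tolerated), and compound 2 `FC(F)(F)c1ccc(-c2nn(-c3ccccc3)cc2-c2nc3ccccc3[nH]2)cc1` gives 167000 nM, so the two stand level. Among the measured compounds shown here, the only measured step is a 1.1-fold lower number from compound 1 to compound 2 (0.05 log units; within the scatter), for trifluoromethyl in place of methyl. Compound 3 `Cc1ccc(-c2nn(-c3ccccc3)cc2-c2nc3ccccc3n2S(=O)(=O)c2ccccc2)cc1` instead has phenylsulfonyl in place of hydrogen on an aromatic nitrogen. For the measured compounds named here, no measured compound carries this group, so that step offers little guidance. A modest step to a lower number is expected in this assay, estimated as a 1.7-fold lower number from compound 1 to compound 3 (0.23 log units; within the scatter). The expected value for compound 3 is 110000 nM, with an estimated range of 40000 nM to 260000 nM.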

Compound 3, half-maximal cytotoxic concentration: 138000 nM
For compound 3 the middle estimate is 1.3-fold (0.10 log units) below the measured one; low and high end bracket the measured number.
By their numbers in this assay, from the lowest: compounds 3, 2 and 1 (each within the scatter of the next).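

Across the compounds shown, the aromatic nitrogen of the core changes for the first time: in this assay, phenylsulfonyl in place of hydrogen gives a 1.4-fold lower number from compound 1 to compound 3 (0.13 log units; within the scatter). This position, next to the ring atom that bears a large group, therefore carries phenylsulfonyl without a step beyond the scatter. Nothing available explains this result.
On these data alone, whether acetyl or a longer alkyl chain on this nitrogen would stand level in this assay remains open. So does whether phenylsulfonyl stands level when trifluoromethyl replaces methyl.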